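A few compounds are considered here, and "the series" means these few. Any claim that something is new, unique, unknown or untested is made for them only; others in the source may bear on it.

Compound 2 `CCCN(CC[C@H]1CC[C@H](NC(=O)/C=C/c2ccccc2Cl)CC1)[C@H]1CCc2nc(N)sc2C1` gives 1.2 nM in an assay on brain for displacement of a labelled ligand from D(3) dopamine receptor (Rattus norvegicus) (on this read-out higher numbers stand for weaker inhibition and lower numbers for stronger inhibition), level with compound 1 `CCCN(CC[C@H]1CC[C@H](NC(=O)/C=C/c2cccc(Cl)c2)CC1)[C@H]1CCc2nc(N)sc2C1`, which gives 1.2 nM. Compound 3 `CCCN(CC[C@H]1CC[C@H](NC(=O)c2cccc(-n3cncn3)c2)CC1)[C@H]1CCc2nc(N)sc2C1` gives 3 nM in this assay, so compound 2 and compound 1 share the lowest number of the three. Compound 4 `CCCN(CC[C@H]1CC[C@H](NC(=O)c2ccc(-c3noc(C)n3)cc2)CC1)[C@H]1CCc2nc(N)sc2C1` differs from compound 2 in one place: 4-(5-methyl-1,2,4-oxadiazol-3-yl)phenyl in place of 2-(2-chlorophenyl)ethenyl on a carbonyl carbon. The measured steps that bear on this are the two in which an aromatic group takes the place of a chlorophenyl-ethenyl group on the carbonyl carbon: a 2.5-fold higher number from compound 2 to compound 3 (0.40 log units; beyond the scatter) and a 2.5-fold higher number from compound 1 to compound 3 (0.40 log units; beyond the scatter). On that basis a modest rise in the number is expected for compound 4, a 2.5-fold higher number from compound 2 to compound 4 (0.40 log units; beyond the scatter). Compound 4 is estimated at 3 nM in this assay, with an expected range from 1.2 nM to 8 nM.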

Compound 4, inhibition constant: 1.3 nM
Beside the measured number, compound 4's estimate is 2.3-fold (0.36 log units) above it; low and high end bracket the measured number.
By their numbers in this assay, from the lowest: compounds 1, 2 and 4 (each within the scatter of the next); then compound 3.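

In this assay, the change on the carbonyl carbon to 4-(5-methyl-1,2,4-oxadiazol-3-yl)phenyl gives a 1.1-fold higher number from compound 2 to compound 4 (0.03 log units; within the scatter) and a 1.1-fold higher number from compound 1 to compound 4 (0.03 log units; within the scatter). Losing the ethenyl link and the chlorine therefore does not by itself raise the number, as compound 3 alone might have suggested. The two groups with a five-membered ring also differ, with a 2.3-fold lower number from compound 3 to compound 4 (0.36 log units; beyond the scatter), but that step changes both the five-membered ring and its place on the phenyl.

Nothing available explains this difference. On these data alone, whether an amine or a carboxylic acid in place of the methyl on the oxadiazole would keep the number stays open.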